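A few compounds are considered here, and "the series" means these few. Any claim that something is new, unique, unknown or untested is made for them only; others in the source may bear on it.

Measured compounds:
compound 1, `C#CCNC1CCc2c(SCCc3cccc(Br)c3)cccc21`: 30500 nM
compound 2, `C#CCNC1CCc2c(SCc3ccc(F)cc3F)cccc21`: 2430 nM

In an assay on isolated protein for inhibition of Amine oxidase [flavin-containing] B (Homo sapiens) (a lower number here means a stronger inhibitor, a higher number a weaker inhibitor), compound 1 gives 30500 nM, the highest of the two numbers, so it is the weaker inhibitor of this pair. Compound 2 gives 2430 nM, a clearly lower number, and the gap between the two lies beyond the scatter. Compound 3, `C#CCNC1CCc2c(SCCc3ccc(Br)cc3)cccc21`, is still to be measured in this assay. It differs from compound 1 in one respect: 4-bromophenyl in place of 3-bromophenyl on a saturated chain carbon, two bonds along the chain from a sulfur. The two compounds share the same atoms, joined differently. Among the measured compounds shown here, no measured pair shows how such a rearrangement moves the number here, so the expectation is loose: the expected step of a 1.5-fold lower number from compound 1 to compound 3 (0.18 log units; within the scatter) is small, within the scatter or only just beyond it, and could go in either direction. On that basis compound 3 is estimated at 20000 nM, with a range from 5000 nM to 80000 nM.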

Compound 3, half-maximal inhibitory concentration: 85300 nM
Beside the measured number, compound 3's estimate is 4.3-fold (0.63 log units) below it, outside the stated range (above it).
By their numbers in this assay, from the lowest: compound 2; then compound 1; then compound 3.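

In this assay, among the compounds shown here, 4-bromophenyl in place of 3-bromophenyl gives a 2.8-fold higher number from compound 1 to compound 3 (0.45 log units; beyond the scatter) and this is the first measured pair that differs in one place. The two compounds share the same atoms, and the counted features of the group stay the same, so where the bromine is joined to the ring is enough to move the number at this position. Nothing available explains why the step goes in this direction.

From the compounds shown here alone, it remains open whether a plain phenyl, a 3-chlorophenyl or a 3-methoxyphenyl on the same chain would land nearer compound 1 or compound 3. Compound 2 differs from compound 1 in more than one place, so the compounds shown cannot separate the effect of the chain from that of the ring groups on its lower number.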